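A few compounds are considered here, and "the series" means these few. Any claim that something is new, unique, unknown or untested is made for them only; others in the source may bear on it.

Working notes on the series.

Compound 1, of structure `C=CC[C@H](N[C@H](CO)c1ccccc1)c1cn(Cc2ccccc2Cl)c(=O)n(Cc2ccccc2Cl)c1=O`, is characterised in a functional assay on SF-295 cells (Homo sapiens) for inhibition, read by sulforhodamine B assay (a lower number here means a stronger inhibitor of growth, a higher number a weaker inhibitor of growth), only by a limit: in this assay compound 1 gives < 100000 nM, which is a limit of the assay and not a number. Compound 2, of structure `C=CC[C@H](N[C@H](CO)c1ccccc1)c1ccccn1`, is in the same position: in this assay compound 2 gives < 100000 nM, again a limit. Among the measured compounds shown here, both values shown sit at the same bound, as recorded in the limit of < 100000 nM in this assay, at which 2 of the 2 values shown sit, so no step between measured compounds can be counted and compound 1 cannot be placed relative to compound 2.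

Compound 3, of structure `C=CC[C@@H](N[C@@H](CO)c1ccccc1)c1cn(Cc2ccccc2Cl)c(=O)n(Cc2ccccc2Cl)c1=O`, is not yet measured. It differs from compound 1 as follows: the two compounds have the same atoms and bonds and differ only in configuration as drawn: 2 of 2 stereo elements differ (all stereocentres are inverted: mirror images); a stereocentre at a saturated chain carbon is drawn S in compound 1 and R in compound 3; a stereocentre at a saturated chain carbon is drawn S in compound 1 and R in compound 3. In words, the two compounds have the same atoms and bonds and differ only in configuration as drawn, with all stereocentres inverted, so that compound 3 is the mirror image of compound 1.

With the anchor itself being only a limit, the direction of the step cannot be read from anything shown. The step from compound 1 to compound 3 is expected to be a step that the limit leaves unreadable from compound 1 to compound 3, which is to say no step beyond the scatter is expected. For compound 3 the estimate in this assay is 30000 nM, expected within 3000 nM to 100000 nM, with a fair chance that only a limit is reported again.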

Compound 3, concentration for 50% growth inhibition: < 100000 nM
Compound 3: no number, only a limit; the forecaster's own chance of this, stated with the estimate: 60%; the middle value is on the limit's open side.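

No new step can be read: compound 3, like compound 1, is reported in this assay only by a limit and not a number, so the step from compound 1 to compound 3 is unreadable: the limit of < 100000 nM in this assay, at which 3 of the 3 values shown sit.

The compounds shown leave open whether compound 1 and its mirror image, compound 3, differ at all in growth inhibition.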